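Oxazolyl in place of the carbonyl group of compound 2

The source may hold more compounds than are shown below. What is called first, only, known or untested is meant among the compounds shown, and "the series" means these compounds.

In an assay on membranes from HeLa cells for displacement of a labelled ligand from adenosine receptor A3 (Homo sapiens), read by scintillation counting, with a stated time of 180 min, tested at 1 uM (a higher number here means more inhibition at the concentration tested (going by the name of the read-out), a lower number less inhibition), compound 1 `CC1=C(C(=O)OC(C)(C)C)C(c2ccsc2)NC(=O)N1` gives 1%, compound 2 `CC1=C(C(=O)CC(C)C)C(c2ccsc2)NC(=O)N1` gives 14% and compound 3 `CCN(CC)C(=O)C1=C(C)NC(=O)NC1c1ccsc1` gives 35%. Compound 2 thus stands second highest of the three, set apart from compound 1 by a number 13 percentage points higher from compound 1 to compound 2 (beyond the scatter) and from compound 3 by a number 21 percentage points higher from compound 2 to compound 3 (beyond the scatter). Compound 4 `CC1=C(c2ncc(C)o2)C(c2ccsc2)NC(=O)N1` differs from compound 2 by 5-methyl-1,3-oxazol-2-yl in place of isobutylcarbonyl on a double-bonded ring carbon. The measured steps each exchange a group on a carbonyl carbon that is kept; none removes the carbonyl itself, so they bear on this step only loosely. They span from a number 13 percentage points higher from compound 1 to compound 2 (beyond the scatter) up to a number 34 percentage points higher from compound 1 to compound 3 (beyond the scatter), so a step of comparable size in either direction, or none beyond the scatter, is plausible. The number for compound 4 in this assay is therefore estimated at 15%, between 0% and 40%, an expected step of a number 1 percentage points higher from compound 2 to compound 4 (within the scatter).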

Compound 4, a percentage reported as inhibition, at one concentration (the size of the read-out at that concentration, not a potency): 2%
Compound 4: middle estimate off by 13 percentage points, on the high side, and the stated range covers the measured number.
By their numbers in this assay, from the lowest: compounds 1 and 4 (each within the scatter of the next); then compound 2; then compound 3.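

Going by these compounds alone, at this position the earlier steps only exchanged a group on a carbonyl carbon that stayed in place, whereas here the carbonyl itself goes. In this assay, 5-methyl-1,3-oxazol-2-yl in place of isobutylcarbonyl gives a number 12 percentage points lower from compound 2 to compound 4 (beyond the scatter), so this aromatic ring does not stand in for the carbonyl group of compound 2 at the double-bonded ring carbon. Nothing on hand accounts for the drop.

Open, as far as these compounds go, is whether the drop belongs to the ring as such or to its methyl group, which an unsubstituted oxazolyl would separate. Also open, from the compounds shown here alone, is whether a carboxylic acid or a longer chain on the kept carbonyl would pass compound 3 at 35%.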